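Replacing the hydroxyethyl chain on the shared core

The compounds below may be only part of what the source reports. "The series", "measured", "known", "first", "only" and "open" are said of these compounds alone.

Compound 1 `O=C1c2ccccc2NS(=O)(=O)N1COCCO` carries a hydroxymethyl on a saturated chain carbon bound to an oxygen on a saturated carbon. In a functional assay on HEL cells (Homo sapiens) for cytotoxicity (on this read-out lower numbers stand for higher toxicity in this test and higher numbers for lower toxicity in this test), compound 1 gives only a limit, > 50 ug/mL, not a number. Compound 2 `CC(=O)OCCOCN1c2ccccc2C(=O)N(Cc2ccccc2)S1(=O)=O` gives 50 ug/mL in this assay, and compound 3 `C#CCOCN1c2ccccc2C(=O)N(Cc2ccccc2)S1(=O)=O` gives 50 ug/mL. Among the compounds with values here, the single measured step, no change at the digits printed from compound 2 to compound 3 (within the scatter), alters the same place and stays within the scatter. Compound 4 `O=C1c2ccccc2NS(=O)(=O)N1COCc1ccccc1` differs from compound 1 by phenyl in place of hydroxymethyl on a saturated chain carbon bound to an oxygen on a saturated carbon. Within the data shown here, no measured step covers a phenyl entering at this place; the only guide is that the one measured step stayed flat, alongside the limit (the limit of > 50 ug/mL in this assay, at which 1 of the 3 values shown sits). No step beyond the scatter is therefore expected. Compound 4 is estimated at 50 ug/mL, with a range from 25 ug/mL to 100 ug/mL, an expected step of a number no higher from compound 1 to compound 4 (the limit leaves the size open).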

Compound 4, minimum cytotoxic concentration: > 50 ug/mL
Compound 4 ended at the assay's limit; the forecaster's own chance of this, stated with the estimate: 50%; the middle value sits exactly at the limit.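

No step can be read between compound 1 and compound 4, since both end at a limit in this assay: the limit of > 50 ug/mL in this assay, at which 2 of the 4 values shown sit.

The compounds shown leave open whether phenyl in place of hydroxymethyl changes the read-out in this assay at all.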